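Sulfonyl aryl exchange in a benzoxazole sulfonamide series

The source may hold more compounds than are shown below. What is called first, only, known or untested is meant among the compounds shown, and "the series" means these compounds.

Compound 1 `O=S(=O)(Nc1ccc2oc(-c3ccccc3)nc2c1)c1ccc(Cl)c(Cl)c1` is the reference point of this account. In an ADME assay on HEK293 cells (Homo sapiens) for cytotoxicity, read by resazurin assay, with a stated time of 48 h (on this read-out higher numbers stand for lower toxicity in this test and lower numbers for higher toxicity in this test), compound 1 gives 71000 nM, the highest of the two numbers shown, its nearest neighbour being compound 3 `O=S(=O)(Nc1ccc2oc(-c3ccccc3)nc2c1)c1ccc(Cl)c(C(F)(F)F)c1`, which gives 66000 nM; the step of a 1.1-fold lower number from compound 1 to compound 3 (0.03 log units; within the scatter) is the only change at the aryl group on the sulfonyl sulfur that has been measured. Compound 2 `O=S(=O)(Nc1ccc(-c2nc3ccccc3o2)cc1)c1cccc(Cl)c1` is reported in this assay only as a limit, > 100000 nM, and the limit of > 100000 nM in this assay, at which 1 of the 3 values shown sits, describes that cut-off.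

Compound 4 `Cc1cccc(S(=O)(=O)Nc2ccc3oc(-c4ccccc4)nc3c2)c1` differs from compound 1 at the same place: 3-methylphenyl in place of 3,4-dichlorophenyl on a sulfonyl sulfur. Going by the values given here, the one measured step that bears on this change, the move from compound 1 to compound 3, stayed within the scatter, so no step beyond the scatter is expected in this assay in either direction. Compound 4 is therefore expected to give 75000 nM, with a range from 38000 nM to 150000 nM. The change a 1.1-fold higher number from compound 1 to compound 4 (0.02 log units; within the scatter) that this estimate implies is expected to remain within the scatter of the measurement.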

Compound 4, half-maximal cytotoxic concentration: 69000 nM
Beside the measured number, compound 4's estimate is 1.1-fold (0.04 log units) above it; low and high end bracket the measured number.
By their numbers in this assay, from the lowest: compounds 3, 4 and 1 (each within the scatter of the next). At a limit, above all of these: compound 2.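

In this assay, the exchange of the whole aryl group on the sulfonyl sulfur gives a 1.0-fold lower number from compound 1 to compound 4 (0.01 log units; within the scatter). Compounds 1, 2 and 3 all carry chlorine on that aryl group, whereas the 3-methylphenyl of compound 4 has only carbon among its heavy atoms, so a number within the scatter of compound 1 does not depend on chlorine being present there. Together with the trifluoromethyl exchange, this gives two different replacements on this aryl group that stay within the scatter, although nothing shown here gives a cause for either step.

The compounds shown leave open whether an amine or a carboxylic acid on this aryl group would hold the number as well. They also leave open what a longer alkyl chain in place of the aryl group would do.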